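Bis(trifluoromethyl)benzenesulfonamides: dropping the ring chloro

This account rests on a few compounds, and the source may have more. Where it says the series, first, only, none or still open, it means among the compounds named here.

Measured so far in a functional assay on BXPC-3 cells (Homo sapiens) for inhibition, read by MTT assay, with a stated time of 72 h; a lower number here means a stronger inhibitor of growth, a higher number a weaker inhibitor of growth:
compound 1 `O=S(=O)(NCCCNCc1ccccc1Cl)c1cc(C(F)(F)F)cc(C(F)(F)F)c1` gives 11000 nM
compound 2 `O=S(=O)(NCCCCNCc1ccc(Br)cc1)c1cc(C(F)(F)F)cc(C(F)(F)F)c1` gives 1700 nM
compound 3 `O=S(=O)(NCCCNCC1COc2ccccc2O1)c1cc(C(F)(F)F)cc(C(F)(F)F)c1` gives 1200 nM

Compound 1 has the highest number of the three. The measured steps both move away from it: a 6.5-fold lower number from compound 1 to compound 2 (0.81 log units; beyond the scatter) and a 9.2-fold lower number from compound 1 to compound 3 (0.96 log units; beyond the scatter).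

Compound 4 `O=S(=O)(NCCCNCc1ccccc1)c1cc(C(F)(F)F)cc(C(F)(F)F)c1` differs from compound 1 by hydrogen in place of chloro on an aromatic carbon. Neither measured step bears on this: each of them changes more of the aryl fragment than the chloro alone, so nothing here gauges a bare hydrogen in place of chloro. The expectation for compound 4 is therefore a step of a 1.1-fold higher number from compound 1 to compound 4 (0.04 log units; within the scatter) in this assay, within the scatter and in no firm direction. Compound 4 is estimated at 12000 nM, with a range from 5000 nM to 30000 nM.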

Compound 4, concentration for 50% growth inhibition: 13000 nM
The estimate for compound 4 lay 1.1-fold (0.03 log units) below the measured number; measured number inside the range.
By their numbers in this assay, from the lowest: compounds 3 and 2 (each within the scatter of the next); then compounds 1 and 4 (each within the scatter of the next).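

In this assay, the isolated swap gives a 1.2-fold higher number from compound 1 to compound 4 (0.07 log units; within the scatter) and so lies within the scatter: the chloro alone does not separate these two compounds. The larger gaps sit with the wider changes, with an 11-fold higher number from compound 3 to compound 4 (1.03 log units; beyond the scatter) on replacing the 2,3-dihydro-1,4-benzodioxin-2-yl group by phenyl, and a 7.6-fold higher number from compound 2 to compound 4 (0.88 log units; beyond the scatter) in a change that alters both chain and ring. No measurement at hand accounts for these gaps.

As far as these compounds go, whether a methoxy or an amine on the same aromatic carbon would behave like chloro remains open. So does how much of the gap to compound 2 comes from the longer chain and how much from the bromo.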